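Working notes: urea-linked quinoline amines in MCF7 growth assay

The compounds below may be only part of what the source reports. "The series", "measured", "known", "first", "only" and "open" are said of these compounds alone.

Measured so far:
compound 1 `COc1cc(NC(C)CCCNC(=O)NCCNC(c2ccccc2)(c2ccccc2)c2ccccc2)c2ncccc2c1` — 45000 nM
compound 2 `O=C1NCCN1C(c1ccccc1)(c1ccccc1)c1ccccc1` — 63000 nM
compound 3 `COc1cc(NC(C)CCCNC(=O)NNC(=O)N(CCO)CCO)c2ncccc2c1` — 29000 nM

Of the compounds shown here, three have been read in a functional assay on MCF7 cells (Homo sapiens) for inhibition, read by MTT assay, with a stated time of 4 days; on this read-out higher numbers stand for weaker inhibition and lower numbers for stronger inhibition. Compound 1 gives 45000 nM, compound 2 gives 63000 nM and compound 3 gives 29000 nM. Compound 3 holds the lowest number of the three; its gap to compound 1 lies within the scatter, so no order between these two can be claimed, whereas its gap to compound 2 lies beyond the scatter. Going by the values given here, no pair of measured compounds differs in one place only, so no single structural step has yet been isolated in this assay.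

Compound 4 `COc1cc(NC(C)CCCNC(=O)Nc2ccc(Cl)c(C(F)(F)F)c2)c2ncccc2c1` is the next to be measured. It differs from compound 3 at one site: 4-chloro-3-(trifluoromethyl)phenyl in place of (bis(2-hydroxyethyl)carbamoyl)amino on an amide-type nitrogen. Among the compounds with values here, no measured pair shows what this kind of exchange does in this assay, so the direction rests on judgement alone. The working expectation is a step toward a lower number for compound 4, of moderate size, a 2.9-fold lower number from compound 3 to compound 4 (0.46 log units; beyond the scatter), though a result within the scatter of compound 3 is not excluded. Compound 4 is estimated at 10000 nM, with a range from 3000 nM to 40000 nM.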

Compound 4, half-maximal inhibitory concentration: 4000 nM
The estimate for compound 4 lay 2.5-fold (0.40 log units) above the measured number; the measured number falls inside the stated range.
By their numbers in this assay, from the lowest: compound 4; then compounds 3, 1 and 2 (each within the scatter of the next, the first and the last beyond it).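

Going by these compounds alone, this is the first single-site step: in this assay, 4-chloro-3-(trifluoromethyl)phenyl in place of (bis(2-hydroxyethyl)carbamoyl)amino on an amide-type nitrogen gives a 7.3-fold lower number from compound 3 to compound 4 (0.86 log units; beyond the scatter), a step beyond the scatter. The position is therefore not silent in this assay, and the lower number does not require the hydroxyl-bearing group: the entering aromatic ring has no hydrogen-bond donors or acceptors. No measured data explain why the number falls.

Within the data shown here, the single step exchanges the whole group, so it does not separate the contributions of the aromatic ring, the chlorine and the trifluoromethyl. Also open, as far as these compounds go, is how an unsubstituted phenyl, a pyridine or a carboxylic acid on the same nitrogen would read in this assay.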